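The compounds below may be only part of what the source reports. "The series", "measured", "known", "first", "only" and "open" are said of these compounds alone.

Among the compounds with values here, in a functional assay on K562 cells (Homo sapiens) for cytotoxicity, read by trypan blue exclusion, with a stated time of 96 h (a lower number here means a stronger inhibitor, a higher number a weaker inhibitor), compound 3 `COc1cc(OC)c(/C=C/S(=O)(=O)Nc2ccc(OC)c(OP(=O)(O)O)c2)c(OC)c1` gives 7.5 nM, the lowest of the three numbers so far, though not separable from compound 2 `COc1cc(OC)c(/C=C/S(=O)(=O)Nc2ccc(OC)c(OC(=O)C(C)(C)C3=C(C)C(=O)C=C(C)C3=O)c2)c(OC)c1` at 8 nM, which lies within the scatter of it. Compound 1 `COc1ccc(NS(=O)(=O)/C=C/c2c(F)c(F)c(F)c(F)c2F)cc1` stands far off at 5000 nM, a gap well beyond the scatter.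

Compound 4 `COC(=O)CNc1cc(NS(=O)(=O)/C=C/c2c(OC)cc(OC)cc2OC)ccc1OC` keeps the rest of compound 3 and changes one group: a group of 6 heavy atoms (3 carbon, 1 nitrogen, 2 oxygen; no ring) in place of a group of 5 heavy atoms (4 oxygen, 1 phosphorus; no ring), on an aromatic carbon. The entering ((methoxycarbonyl)methyl)amino sits on an aromatic carbon, ortho to a methoxy group and meta to a large group.

Within the data shown here, no step between measured compounds is available to size this change. Among the measured compounds shown here, the only guide is that compound 2 at 8 nM and compound 3 at 7.5 nM both read low in this assay. A modest move towards weaker inhibition is therefore expected, with an estimated 4.0-fold higher number from compound 3 to compound 4 (0.60 log units; beyond the scatter). The expected value for compound 4 is 30 nM, with an estimated range of 8 nM to 150 nM.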

Compound 4, half-maximal inhibitory concentration: 350 nM
The estimate for compound 4 lay 12-fold (1.07 log units) below the measured number; measured number above the stated range.
By their numbers in this assay, from the lowest: compounds 3 and 2 (each within the scatter of the next); then compound 4; then compound 1.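

In this assay, within the data shown here, the step of a 47-fold higher number from compound 3 to compound 4 (1.67 log units; beyond the scatter) shows that this position, on an aromatic carbon ortho to a methoxy group, is not indifferent to what it carries, since the single exchange is enough to produce a large change with the rest of the structure held constant. The ((methoxycarbonyl)methyl)amino group is therefore not an equivalent replacement for the group that leaves, even though the two are close in heavy-atom count. Nothing available explains the size of this step.

With one step at this position, the attached nitrogen cannot be separated from the methyl ester end of the chain as the part that matters. A plain amine or the corresponding carboxylic acid at this position would help to divide the change into those two parts.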